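This account rests on a few compounds, and the source may have more. Where it says the series, first, only, none or still open, it means among the compounds named here.

Measured so far:
compound 1 `Cc1cc(C)c2c(O)cc(-c3cccc(F)c3)nc2n1`: 33.1 nM
compound 2 `Cc1cc(C)c2c(O)cc(-c3cccc4ccccc34)nc2n1`: 589 nM

In a functional assay on SF-295 cells (Homo sapiens) for antiproliferative activity (on this read-out lower numbers stand for stronger inhibition of growth and higher numbers for weaker inhibition of growth), compound 1 has the lower of the two numbers, and the gap to compound 2 lies beyond the scatter. Compound 3 `Cc1cccc(-c2cc(O)c3c(C)cc(C)nc3n2)c1` differs from compound 1 in one place, with methyl in place of fluoro on an aromatic carbon. Going by the values given here, no measured pair shows this change, so the expectation in this assay is only a modest move toward a higher number, not far beyond the scatter. The expected step is a 1.8-fold higher number from compound 1 to compound 3 (0.26 log units; within the scatter). For compound 3 the estimated value is 60 nM, with an expected range from 20 nM to 200 nM.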

Compound 3, concentration for 50% growth inhibition: 64600 nM
The estimate for compound 3 lay 1100-fold (3.03 log units) below the measured number; measured number outside the range, above it.
By their numbers in this assay, from the lowest: compound 1; then compound 2; then compound 3.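

In this assay, this place on the aromatic ring, meta to a large group, proves highly sensitive: methyl in place of fluoro gives a 2000-fold higher number from compound 1 to compound 3 (3.29 log units; beyond the scatter). The exchange swaps one heavy atom for one and leaves the counts of rings, hydrogen-bond donors and acceptors and the net charge unchanged, so a very small change in these terms is enough for a large loss. No available evidence bears on the reason for this loss.

The compounds shown leave open whether fluoro is specifically favoured or methyl specifically disfavoured here. Plain hydrogen, chloro, methoxy or an amine at this place could separate those two readings.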